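Isopropyl for 2-hydroxypropyl: solubility of compound 4 expected

This account rests on a few compounds, and the source may have more. Where it says the series, first, only, none or still open, it means among the compounds named here.

compound 1, `CCN(CC)Cc1ccc(-c2cnc(N)c(C(=O)NC[C@@](C)(O)C(F)(F)F)n2)cc1`, > 1000000 nM (a limit)
compound 2, `CC(O)CNC(=O)c1nc(-c2ccc(CN(C)C)cc2)cnc1N`, > 1000000 nM (a limit)
compound 3, `CCN(CC)C1CCN(Cc2ccc(-c3cnc(N)c(C(=O)N[C@H]4CC[C@H](O)CC4)n3)cc2)CC1`, > 1000000 nM (a limit)

Of the compounds shown here, three have been measured in a physicochemical assay for solubility, at pH 6.8; on this read-out higher numbers stand for higher solubility and lower numbers for lower solubility. In this assay compound 1 gives > 1000000 nM, which is a limit of the assay rather than a number. Compound 2 likewise gives > 1000000 nM, again a limit. Compound 3 gives > 1000000 nM, also a limit. So all three sit at the same ceiling: the limit of > 1000000 nM in this assay, at which 3 of the 3 values shown sit. Compound 2 therefore stands at the limit, like every other value shown, and no numerical difference between the compounds is known.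

Compound 4, `CC(C)NC(=O)c1nc(-c2ccc(CN(C)C)cc2)cnc1N`, has not yet been measured. It differs from compound 2 in one place: isopropyl in place of 2-hydroxypropyl on an amide-type nitrogen. For the measured compounds named here, since no measured step is available for this kind of change, the expectation rests on compound 2 alone, whose value in this assay is > 1000000 nM.

The step of a number no higher from compound 2 to compound 4 (the limit leaves the size open) is expected to be small, if any, with a downward direction more likely than an upward one. Compound 4 is estimated at 1000000 nM, within a range from 150000 nM to 1000000 nM.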

Compound 4, solubility: > 1000000 nM
Compound 4: no number, only a limit (the forecaster's own chance of this, stated with the estimate: 65%); the middle value sits exactly at the limit.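

In this assay compound 4 gives > 1000000 nM as a limit of the assay and not a number. For the compounds shown here, no step from compound 2 to compound 4 can be read, because both compounds stand at the same ceiling: the limit of > 1000000 nM in this assay, at which 4 of the 4 values shown sit.

The compounds shown leave open whether isopropyl in place of 2-hydroxypropyl on an amide-type nitrogen changes the read-out of this assay at all, and in which direction.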